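A few compounds are considered here, and "the series" means these few. Any claim that something is new, unique, unknown or untested is made for them only; others in the source may bear on it.

In a functional assay on PC-3 cells (Homo sapiens) for antiproliferative activity, read by MTT assay, with a stated time of 72 h (a lower number here means a stronger inhibitor, a higher number a weaker inhibitor), compound 1 `CCN(CC)C(=S)SCC1=CCOC1=O` gives 57100 nM and compound 2 `CNC(=S)SCC1=CCOC1=O` gives 76500 nM, a change of a 1.3-fold higher number from compound 1 to compound 2 (0.13 log units; within the scatter), so compound 2 holds the higher of the two numbers, yet the pair sits within the scatter. Compound 3 `CC(C)NC(=S)SCC1=CCOC1=O` differs from compound 2 by isopropyl in place of methyl on an amide-type nitrogen. Among the compounds with values here, the only measured step, the move from a diethylamino group to a methylamino group, barely moved the number, so the larger amine of compound 3 is expected to change little, giving an expected step of a 1.1-fold lower number from compound 2 to compound 3 (0.04 log units; within the scatter). Compound 3 is therefore estimated at 70000 nM, within a range from 35000 nM to 140000 nM.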

Compound 3, half-maximal inhibitory concentration: 49400 nM
For compound 3 the middle estimate is 1.4-fold (0.15 log units) above the measured one; the range from low to high includes it.
By their numbers in this assay, from the lowest: compounds 3, 1 and 2 (each within the scatter of the next).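

Isopropyl in place of methyl on the amide-type nitrogen gives a 1.5-fold lower number from compound 2 to compound 3 (0.19 log units; within the scatter) in this assay, and isopropylamino in place of diethylamino gives a 1.2-fold lower number from compound 1 to compound 3 (0.06 log units; within the scatter) in the same test. Isopropylamino thus joins methylamino and diethylamino as a third group on the thiocarbonyl carbon, with every printed step within the scatter. Nothing available explains this flat result.

As far as these compounds go, whether a phenylamino group or a morpholine ring at this position would move the number beyond the scatter remains open, as does the effect of changing the shared core.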